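The compounds below may be only part of what the source reports. "The series", "measured", "known", "first", "only" and "open" are said of these compounds alone.

Working notes on the series. Compound 1 `N#CC1=C(N)Oc2c(c3nc4ccccc4nc3c3ccccc23)C12C(=O)N(Cc1cnnn1-c1ccccc1Br)c1ccccc12` and compound 2 `CC(=O)Nc1ccc(-n2nncc2CN2C(=O)C3(C(C#N)=C(N)Oc4c(N)cc5nc6ccccc6nc5c43)c3ccccc32)cc1` share one core, and differ only on the aromatic nitrogen of the five-membered ring with 3 nitrogen. In a functional assay on A549 cells (Homo sapiens) for antiproliferative activity, read by MTT assay, with a stated time of 48 h (a lower number here means a stronger inhibitor, a higher number a weaker inhibitor), compound 1 gives > 50000 nM, which is a limit of the assay and not a number. In this assay compound 2 gives > 50000 nM, likewise a limit rather than a number. Going by the values given here, compound 2 therefore stands at the edge of what can be read, as does the one other value shown (the limit of > 50000 nM in this assay, at which 2 of the 2 values shown sit). Compound 3 `Cc1ccc(-n2nncc2CN2C(=O)C3(C(C#N)=C(N)Oc4c(N)cc5nc6ccccc6nc5c43)c3ccccc32)cc1Cl` carries 3-chloro-4-methylphenyl in place of 4-acetamidophenyl on an aromatic nitrogen. Among the compounds with values here, no measured step between two compounds is available to size this change against. Nothing in the two values shown points to a step beyond the scatter in either direction from compound 2 to compound 3, so the expected step is a number no higher from compound 2 to compound 3 (the limit leaves the size open). Compound 3 is therefore expected to give about 50000 nM in this assay, within 15000 nM to 200000 nM, most likely again as a limit.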

Compound 3, half-maximal inhibitory concentration: 11800 nM
The estimate for compound 3 lay 4.2-fold (0.63 log units) above the measured number; measured number below the stated range.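

The aromatic nitrogen of the five-membered aromatic ring with 3 nitrogen is now shown to be a place where the group matters in this assay: 3-chloro-4-methylphenyl in place of 4-acetamidophenyl gives an at least 4.2-fold lower number from compound 2 to compound 3 (0.62 log units; beyond the scatter). The change replaces a ring bearing a hydrogen-bond donor and acceptor with one bearing neither, but this single pair cannot separate the loss of the acetamide from the gain of chlorine and methyl. The true size of the step stays unknown, because compound 2 gives a limit and not a number: the limit of > 50000 nM in this assay, at which 2 of the 3 values shown sit.

The compounds shown leave open whether chlorine or methyl alone on the phenyl ring would give the same step. From the compounds shown here alone, how a methoxy group, a fluorine or an amine on that ring would read also remains open.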